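Swapping the Aryl Group on Compound 2

The source may hold more compounds than are shown below. What is called first, only, known or untested is meant among the compounds shown, and "the series" means these compounds.

Compound 1 `CNC(=O)c1ccccc1Oc1nc(Nc2cccc(OC)c2)ncc1Br` gives 17800 nM
Compound 2 `Cc1cccc(Nc2ncc(Br)c(Oc3cccc(F)c3)n2)c1` gives 29200 nM
Compound 3 `Cc1cccc(Nc2ncc(Br)c(Oc3cccc([N+](=O)[O-])c3)n2)c1` gives 36700 nM

These three values come from a functional assay on MDA-MB-468 cells (Homo sapiens) for antiproliferative activity, read by MTT assay, with a stated time of 24 h (a higher number here means a weaker inhibitor, a lower number a stronger inhibitor), and lie close together. Compound 2 (29200 nM) holds the middle place, and the other two numbers both fall within the usual scatter of it. Compound 4 `Cc1cccc(Nc2ncc(Br)c(Oc3ccc(Br)cc3)n2)c1` differs from compound 2 in one place, with 4-bromophenyl in place of 3-fluorophenyl on an oxygen on an aromatic ring. Among the compounds with values here, no measured compound carries this 4-bromophenyl group, so the evidence is indirect. Within the data shown here, the only measured step that bears on it is a 1.3-fold higher number from compound 2 to compound 3 (0.10 log units; within the scatter) when nitro takes the place of fluoro on an aromatic carbon. That single step stayed within the scatter, so no clear change is expected here, and no direction can be favoured with confidence. The estimate amounts to a 1.1-fold lower number from compound 2 to compound 4 (0.03 log units; within the scatter) and no real shift is expected in this assay from this swap. For compound 4 the estimated value is 27000 nM (range 13000 nM to 55000 nM).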

Compound 4, half-maximal inhibitory concentration: 31300 nM
Estimate against measurement, compound 4: 1.2-fold (0.06 log units) below, within the range that was stated.
By their numbers in this assay, from the lowest: compounds 1, 2, 4 and 3 (each within the scatter of the next, the first and the last beyond it).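

In this assay, the 4-bromophenyl group on the oxygen gives a 1.1-fold higher number from compound 2 to compound 4 (0.03 log units; within the scatter) and so reads the same as the 3-fluorophenyl group. Within the data shown here, until now, the only swap seen on this aryl group was nitro for fluoro; this result adds a second swap within the scatter, one that exchanges the halogen and also its printed ring number. Nothing measured here offers an explanation for this result.

As far as these compounds go, with both the halogen and its ring number exchanged at once, the effect of each alone remains unknown, and a 4-fluorophenyl group would separate them. From the compounds shown here alone, it also remains open whether an amine or a carboxylic acid on this ring, or a plain alkyl chain in place of the ring, would move the number beyond the scatter.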